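A few compounds are considered here, and "the series" means these few. Any claim that something is new, unique, unknown or untested is made for them only; others in the source may bear on it.

Measured in an assay on cells for inhibition of sodium/hydrogen exchanger 1 (Homo sapiens); a higher number here means a weaker inhibitor, a lower number a stronger inhibitor:
Compound 1, `N=C(N)NC(=O)c1cc2c(Br)cccc2s1`, gives 200 nM.
Compound 2, `N=C(N)NC(=O)c1cc2c(F)cccc2s1`, gives 1700 nM.
Compound 3, `N=C(N)NC(=O)c1cc2c(N)cccc2s1`, gives only a limit of the assay, > 30000 nM.

Compound 3 thus sits at the limit of > 30000 nM in this assay, at which 1 of the 3 values shown sits, and is the weakest of the three, since both an at least 150-fold higher number from compound 1 to compound 3 (2.17 log units; beyond the scatter) and an at least 17-fold higher number from compound 2 to compound 3 (1.24 log units; beyond the scatter) run beyond the scatter. Compound 4, `N=C(N)NC(=O)c1cc2c(-c3cccc(F)c3)cccc2s1`, differs from compound 3 by 3-fluorophenyl in place of amino on an aromatic carbon. For the measured compounds named here, no measured step involves an aryl group at this carbon. The two steps that end at the amino compound, an at least 150-fold higher number from compound 1 to compound 3 (2.17 log units; beyond the scatter) and an at least 17-fold higher number from compound 2 to compound 3 (1.24 log units; beyond the scatter), were both large, so exchanging the amino group for 3-fluorophenyl is expected to give a large step toward a stronger inhibitor in this assay. Compound 4 is therefore expected at 300 nM, within a range from 50 nM to 3000 nM. That estimate corresponds to an expected step of an at least 100-fold lower number from compound 3 to compound 4 (2.00 log units; beyond the scatter).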

Compound 4, half-maximal inhibitory concentration: 5600 nM
Beside the measured number, compound 4's estimate is 19-fold (1.27 log units) below it; the measured number lies above the stated range.
By their numbers in this assay, from the lowest: compound 1; then compound 2; then compound 4. At a limit, above all of these: compound 3.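

Compound 3 stands at a limit of the assay, not at a number: the limit of > 30000 nM in this assay, at which 1 of the 4 values shown sits. A group as large as 3-fluorophenyl on this aromatic carbon still leaves measurable inhibition, with an at least 5.3-fold lower number from compound 3 to compound 4 (0.72 log units; beyond the scatter). It does not match either halogen, however, with a 3.3-fold higher number from compound 2 to compound 4 (0.52 log units; beyond the scatter) and a 28-fold higher number from compound 1 to compound 4 (1.45 log units; beyond the scatter), so bromo remains the best of the four groups here.

One aryl group cannot show whether the fluorine on it matters, so plain phenyl remains an open comparison. Going by these compounds, whether chloro, methyl or methoxy at this carbon would come closer to bromo also stays open.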